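One fluoro added to compound 2

The source may report more compounds than this note shows. Statements on the series, on what has been measured and on what is new or still open speak of the compounds shown alone.

Compound 1 `O=C(Nc1ccccc1)Nc1cccc(Nc2nccc(Nc3ccc4nc[nH]c4c3)n2)c1` gives 11000 nM
Compound 2 `O=C(Nc1ccccc1)Nc1ccc(Nc2nccc(Nc3ccc4cn[nH]c4c3)n2)cc1` gives 11000 nM

Both values come from a functional assay on HepG2 cells (Homo sapiens) for inhibition, read by fluorescence and resazurin assay, with a stated time of 72 h (a lower number here means a stronger inhibitor, a higher number a weaker inhibitor), and, on these numbers, compound 2 stands level with compound 1, within the usual scatter. The two compounds differ in more than one place, so they do not show what any single change does.

Compound 3 `O=C(Nc1ccc(Nc2nccc(Nc3ccc4cn[nH]c4c3)n2)cc1)Nc1cccc(F)c1` is compound 2 with one small edit, phenyl to 3-fluorophenyl (fluoro in place of hydrogen on an aromatic carbon), which places fluoro in place of hydrogen on an aromatic carbon. Going by the values given here, nothing measured so far shows what this edit does, so the estimate stays close to compound 2 (11000 nM). The expected step (a 1.2-fold lower number from compound 2 to compound 3 (0.09 log units; within the scatter)) is a slight move toward stronger inhibition, with nothing expected beyond the scatter of this assay in either direction. The estimated value for compound 3 is 9000 nM (expected range 3500 nM to 22000 nM).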

Compound 3, half-maximal inhibitory concentration: 6600 nM
Compound 3: middle estimate off by 1.4-fold (0.13 log units), on the high side; the measured number falls inside the stated range.
By their numbers in this assay, from the lowest: compounds 3, 1 and 2 (each within the scatter of the next).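

In this assay, going by these compounds alone, the change from phenyl to 3-fluorophenyl gives the first step that can be read at a single place, a 1.7-fold lower number from compound 2 to compound 3 (0.22 log units; within the scatter) and so no shift that can be told apart from repeat-to-repeat noise. This means that one fluoro in place of hydrogen on this aromatic carbon, meta to a large group, is accepted without a detectable loss or gain in this cell assay. No supporting measurement bears on this result.

The compounds shown leave open whether a bigger or differently natured group at the same carbon, such as a methoxy group, an amine or a carboxylic acid, would move the number beyond the scatter. They also leave open whether a fluoro elsewhere on this ring would behave the same way.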